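A few compounds are considered here, and "the series" means these few. Any claim that something is new, unique, unknown or untested is made for them only; others in the source may bear on it.

Among the compounds with values here, in a functional assay on K562 cells (Homo sapiens) for antiproliferative activity, read by MTT assay, with a stated time of 48 h (on this read-out lower numbers stand for stronger inhibition of growth and higher numbers for weaker inhibition of growth), compound 2 `COc1ccc(N(C)c2nc(Cl)nc3c2ncn3C)cc1` gives 2300 nM, the only true number among the three compounds measured so far. Compound 1 `COc1ccc(N(C)c2ncnc3c2ncn3C)cc1` reads > 100000 nM, which is a limit of the assay and not a number. Compound 3 `COc1ccc(N(C)c2ncnc3c2ncn3Cc2ccc(OC)c(OC)c2)cc1` reads > 100000 nM, which is again a limit. Putting chloro in place of hydrogen on an aromatic carbon gave an at least 43-fold lower number from compound 1 to compound 2 (1.63 log units; beyond the scatter), and compound 4 `COc1ccc(Cn2cnc3c(N(C)c4ccc(OC)cc4)nc(Cl)nc32)cc1` keeps that chloro.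

Compound 4 departs from compound 2 by 4-methoxyphenyl in place of hydrogen on a saturated chain carbon bound to an aromatic nitrogen, which turns methyl into 4-methoxybenzyl. Within the data shown here, the nearest precedent is 3,4-dimethoxyphenyl at the same place, but that is a step that the two limits leave unreadable from compound 1 to compound 3, and it was made on a compound without the chloro. It therefore gives neither a size nor a direction, and the range must stay wide. The best guess is little net change, with the estimated shift being a 1.3-fold higher number from compound 2 to compound 4 (0.12 log units; within the scatter). For compound 4, the expected value is 3000 nM, with an estimated range of 500 nM to 30000 nM.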

Compound 4, concentration for 50% growth inhibition: > 100000 nM
Compound 4: only a limit was reported (the forecaster's own chance of this, stated with the estimate: 15%); at least 33-fold (1.52 log units) between middle value and limit.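

On the saturated chain carbon bound to an aromatic nitrogen, turning methyl into 4-methoxybenzyl gives an at least 43-fold higher number from compound 2 to compound 4 (1.63 log units; beyond the scatter) in this assay. Within the data shown here, this is the first readable size and direction for a change at this position, as the earlier step with 3,4-dimethoxyphenyl cannot be read, and it shows that keeping the chloro does not by itself preserve a measurable value. The size is only a minimum, as compound 4 reads at a limit and not a number: the limit of > 100000 nM in this assay, at which 3 of the 4 values shown sit.

The compounds shown leave open whether methyl is the only group here that gives a measurable value, or whether an ethyl group, a longer chain or an unsubstituted benzyl would also do so. They also leave open whether the methoxy group on the ring matters, or the benzyl group alone already accounts for the loss.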